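A few compounds are considered here, and "the series" means these few. Any claim that something is new, unique, unknown or untested is made for them only; others in the source may bear on it.

Measured so far:
- Compound 1, `Cc1cccc(S(=O)(=O)N2CC(c3nc(-c4cccc(Cl)c4)no3)C2)c1`: 390 nM in an assay on HEK293 cells for negative allosteric modulation of metabotropic glutamate receptor 5 (Homo sapiens), read by FLIPR; a higher number here means a weaker inhibitor, a lower number a stronger inhibitor
- Compound 2, `Cc1ccc(S(=O)(=O)N2CC(c3nc(-c4cccc(Cl)c4)no3)C2)cc1`: in this assay compound 2 gives 920 nM
- Compound 3, `O=S(=O)(c1ccc(F)cc1)N1CC(c2nc(-c3cccc(Cl)c3)no2)C1`: in this assay compound 3 gives 130 nM

Compound 3 stands lowest of the three numbers, and is thus the strongest inhibitor shown; its nearest neighbour is compound 1, with a 3.0-fold lower number from compound 1 to compound 3 (0.48 log units; beyond the scatter), and its furthest is compound 2, with a 7.1-fold lower number from compound 2 to compound 3 (0.85 log units; beyond the scatter). The third step, a 2.4-fold higher number from compound 1 to compound 2 (0.37 log units; beyond the scatter), shows that moving a group around the ring on the sulfonyl sulfur also matters.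

Compound 4, `O=S(=O)(c1ccc(Cl)cc1)N1CC(c2nc(-c3cccc(Cl)c3)no2)C1`, differs from compound 3 in one place: chloro in place of fluoro on an aromatic carbon. Within the data shown here, no measured step swaps one halogen for another, so the closest guide is the step from compound 2 to compound 3, which exchanged a group in the same place. A change within the scatter or a modest lowering is expected, a 1.3-fold lower number from compound 3 to compound 4 (0.11 log units; within the scatter), so compound 4 is estimated at 100 nM, between 40 nM and 300 nM.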

Compound 4, half-maximal inhibitory concentration: 170 nM
Compound 4: the middle estimate sits 1.7-fold (0.23 log units) below what was measured; the range from low to high includes it.
By their numbers in this assay, from the lowest: compounds 3 and 4 (each within the scatter of the next); then compound 1; then compound 2.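

Exchanging one halogen for the other at this place makes no clear difference: a 1.3-fold higher number from compound 3 to compound 4 (0.12 log units; within the scatter) in this assay means 4-fluorophenyl and 4-chlorophenyl cannot be told apart here. Chloro, like fluoro before it, stands clearly apart from methyl on the same carbon, with a 5.4-fold lower number from compound 2 to compound 4 (0.73 log units; beyond the scatter) as the new measure of that gap, and 4-chlorophenyl also differs from 3-methylphenyl, with a 2.3-fold lower number from compound 1 to compound 4 (0.36 log units; beyond the scatter) as the step. Nothing available gives a reason for the gap between methyl and the halogens.

Going by these compounds, whether bromo, methoxy or trifluoromethyl at this place would track the halogens or the methyl remains open. So does how 3-chlorophenyl on the sulfonyl sulfur would compare with 4-chlorophenyl.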